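Chloro for Methyl in a Low-Toxicity Pyrazole Series

This account rests on a few compounds, and the source may have more. Where it says the series, first, only, none or still open, it means among the compounds named here.

Compound 1 `Cc1ccccc1-c1nn(-c2cccc(Cl)c2)cc1CNCCN1CCN(C)CC1` was measured in an ADME assay on Huh-7 cells (Homo sapiens) for cytotoxicity (on this read-out higher numbers stand for lower toxicity in this test and lower numbers for higher toxicity in this test), and gives 16000 nM. For compound 2 `COc1ccc(-n2cc(CNCCN3CCN(C)CC3)c(-c3ccccc3C)n2)cc1` the value > 20000 nM is a limit of the assay, not a number. For compound 3 `Cc1ccccc1-c1nn(-c2ccc(F)cc2F)cc1CNCCN1CCN(C)CC1` the value > 20000 nM is likewise a limit. Compound 3 therefore stands at the limit of > 20000 nM in this assay, at which 2 of the 3 values shown sit.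

Compound 4 `CN1CCN(CCNCc2cn(-c3ccc(F)cc3F)nc2-c2ccccc2Cl)CC1` differs from compound 3 by chloro in place of methyl on an aromatic carbon. The steps measured so far, an at least 1.2-fold higher number from compound 1 to compound 2 (0.09 log units; that floor lies within the scatter), an at least 1.2-fold higher number from compound 1 to compound 3 (0.09 log units; that floor lies within the scatter) and a step that the two limits leave unreadable from compound 2 to compound 3, all swap the group on the aromatic nitrogen and so do not bear on this change. No shift beyond the scatter is expected for compound 4. Compound 4 is expected at 25000 nM, within 12000 nM to 60000 nM. The step that the limit leaves unreadable from compound 3 to compound 4 is the estimate this implies.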

Compound 4, half-maximal cytotoxic concentration: > 20000 nM
Compound 4: only a limit was reported; the forecaster's own chance of this, stated with the estimate: 70%; the middle value is on the limit's open side.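

Compound 3 and compound 4 each carry only a limit in this assay, not a number, so no step between them can be read: the limit of > 20000 nM in this assay, at which 3 of the 4 values shown sit.

On these data alone, whether chloro in place of methyl changes the toxicity in this test at all, and by how much, stays open.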